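The source may hold more compounds than are shown below. What is called first, only, known or untested is meant among the compounds shown, and "the series" means these compounds.

Measured in a functional assay on SKBR cells (Homo sapiens) for cytotoxicity, read by resazurin assay, with a stated time of 72 h; a lower number here means a stronger inhibitor, a higher number a weaker inhibitor:
Compound 1 `COc1cc(/C=C/C(=O)OCCCCCCO[N+](=O)[O-])ccc1O`: 15200 nM
Compound 2 `O=C(/C=C/c1ccc(OCCCCCO[N+](=O)[O-])c(O)c1)OCCCCCO[N+](=O)[O-]`: 2710 nM
Compound 3 `COc1cc(/C=C/C(=O)OCCCCCO[N+](=O)[O-])ccc1O`: 8060 nM

Compound 3 gives 8060 nM, which lies within the scatter of the value for compound 1. Compound 2 gives a clearly lower number, 2710 nM, and this gap is beyond the scatter.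

Compound 4 `COc1cc(/C=C/C(=O)OCCCCCO[N+](=O)[O-])ccc1OCCCCCO[N+](=O)[O-]` is built from compound 3 by one change: 5-(nitrooxy)pentyl in place of hydrogen on an oxygen on an aromatic ring. The hydroxy thus becomes (5-(nitrooxy)pentyl)oxy.

Among the measured compounds shown here, only one measured step changes a single place, a 1.9-fold lower number from compound 1 to compound 3 (0.28 log units; within the scatter). It concerns a different chain and stays within the scatter, so it offers little guidance here. The closer hint comes from compound 2, which already carries this group on an oxygen on an aromatic ring and gives 2710 nM. However, compound 2 differs from compound 3 in more than one place, so its lower number cannot be credited to this group alone.

A modest move towards a lower number in this assay is therefore expected, of a size near the edge of the scatter. The expected step is a 1.8-fold lower number from compound 3 to compound 4 (0.25 log units; within the scatter). For compound 4 the estimated value is 4500 nM, with an expected range from 1800 nM to 11000 nM.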

Compound 4, half-maximal inhibitory concentration: > 50000 nM
Compound 4: no number, only a limit; the forecaster's own chance of this, stated with the estimate: 4%; middle value at least 11-fold (1.04 log units) away from the limit.
By their numbers in this assay, from the lowest: compound 2; then compounds 3 and 1 (each within the scatter of the next). At a limit, above all of these: compound 4.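

In this assay, compound 4 has no number, only a limit: the limit of > 50000 nM in this assay, at which 1 of the 4 values shown sits.

Seen against its neighbours, this is the first sign that the oxygens on the aromatic ring are sensitive to what they carry: 5-(nitrooxy)pentyl in place of hydrogen gives an at least 6.2-fold higher number from compound 3 to compound 4 (0.79 log units; beyond the scatter), and methyl in place of hydrogen on the other such oxygen gives an at least 18-fold higher number from compound 2 to compound 4 (1.26 log units; beyond the scatter). Compounds 1, 2 and 3 each keep a hydroxy on the aromatic ring and compound 4 alone has none, so among these four compounds a free hydroxy goes with a measurable number, and compound 2 shows that 5-(nitrooxy)pentyl on one of these oxygens does not by itself remove it.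

As far as these compounds go, whether the loss follows from capping the hydroxy as such or from the particular groups placed there stays open, since no other group on these oxygens appears, such as an ethyl group, an acetyl group or a chain ending in a carboxylic acid. The compounds shown also leave open whether the same pattern would hold on a core with a longer chain on the ester side.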